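Cyclising the terminal amide: compound 2 to compound 3

A few compounds are considered here, and "the series" means these few. Any claim that something is new, unique, unknown or untested is made for them only; others in the source may bear on it.

Two members of the series have numbers in an assay on HEK293 cells for displacement of a labelled ligand from melanin-concentrating hormone receptor 1 (Homo sapiens); a lower number here means a stronger inhibitor, a higher number a weaker inhibitor. Compound 1 (`O=C(NCc1ccc(Cl)cc1O)C1CCN(Cc2ccn(-c3ccc(C(F)(F)F)cc3)c2)CC1`) gives 22 nM. Compound 2 (`CCN(CC)C(=O)C1CCCN(C(=O)CC2CCN(Cc3ccn(-c4ccc(C(F)(F)F)cc4)c3)CC2)C1`) gives 37 nM. Compound 2 carries the higher of the two numbers, but the gap to compound 1 lies within the scatter, so on this evidence the two are read as equivalent.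

Compound 3 (`O=C(CC1CCN(Cc2ccn(-c3ccc(C(F)(F)F)cc3)c2)CC1)N1CCCC(C(=O)N2CCCC2)C1`) is the next member to be measured in this assay. Relative to compound 2 the change is pyrrolidin-1-yl in place of diethylamino on a carbonyl carbon: the open diethylamino group is exchanged for a ring with the same heavy-atom count, the rest of the molecule untouched. Within the data shown here, no measured pair shows this kind of exchange, so there is no step to lean on. The change is small and the counted donors, acceptors and charge do not move, so the expected step is none beyond the scatter, in either direction. Compound 3 is therefore expected at 32 nM, between 11 nM and 95 nM. That estimate means a step of a 1.2-fold lower number from compound 2 to compound 3 (0.06 log units; within the scatter), which is expected to stay within the scatter.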

Compound 3, half-maximal inhibitory concentration: 71 nM
Compound 3: the middle estimate sits 2.2-fold (0.35 log units) below what was measured; measured number inside the range.
By their numbers in this assay, from the lowest: compounds 1, 2 and 3 (each within the scatter of the next, the first and the last beyond it).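

In this assay the series now has its first pair differing in one place, and the step reads a 1.9-fold higher number from compound 2 to compound 3 (0.28 log units; within the scatter) on exchanging diethylamino for pyrrolidin-1-yl on a carbonyl carbon. At this position, the open diethylamino group can therefore be closed into a five-membered non-aromatic ring, with the heavy-atom count and the counted donors and acceptors unchanged, without a difference beyond the scatter. The single pair gives no sign that ring closure at this carbonyl carbon matters for the number, and no measurement shown accounts for the step in either direction.

Still open, going by these compounds, is how far this position reaches beyond these two groups: a larger ring such as piperidin-1-yl, a ring with a second hetero atom such as morpholin-4-yl, a smaller open amine such as dimethylamino, or a secondary amide that keeps the amide hydrogen would each test it further. A carboxylic acid in place of the whole diethylcarbamoyl group would show whether the amide carbonyl and its nitrogen substituents are needed at all.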